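The source may hold more compounds than are shown below. What is called first, only, known or untested is meant among the compounds shown, and "the series" means these compounds.

Measured so far in an ADME assay on A549 cells (Homo sapiens) for cytotoxicity, read by CellTiter-Glo; on this read-out higher numbers stand for lower toxicity in this test and lower numbers for higher toxicity in this test:
- compound 1 `Cc1c(Cc2ccc(Cl)cc2)c(=O)oc2cc(OCC(O)CN3CCC(C(N)=O)CC3)ccc12`: 40000 nM
- compound 2 `Cc1c(Cc2ccc(F)cc2Cl)c(=O)oc2cc(OCC(O)CN3CCC(C(N)=O)CC3)ccc12`: 90800 nM

Among the compounds with values here, compound 1 gives the lowest of the two numbers in this assay; the only other compound, compound 2, sits at a 2.3-fold higher number from compound 1 to compound 2 (0.36 log units; beyond the scatter) from it, a modest step that nonetheless lies beyond the scatter. Compound 3 `Cc1c(Cc2ccc(-c3ccc(C(F)(F)F)cc3)cc2)c(=O)oc2cc(OCC(O)CN3CCC(C(N)=O)CC3)ccc12` is not yet measured in this assay. Its difference from compound 1 is 4-(trifluoromethyl)phenyl in place of chloro on an aromatic carbon. Within the data shown here, the single measured step, from compound 1 to compound 2, swaps one halogenated phenyl for another and so bears only loosely on the entry of a 4-(trifluoromethyl)phenyl group in place of chloro; it shows that a change at this phenyl can move the number by a modest amount, but it gives no direction for an added ring. The expectation for compound 3 in this assay is therefore a small shift, a 1.6-fold lower number from compound 1 to compound 3 (0.20 log units; within the scatter), with the estimate for compound 3 at 25000 nM, within 8000 nM to 80000 nM.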

Compound 3, half-maximal cytotoxic concentration: > 100000 nM
Compound 3: no number, only a limit; the forecaster's own chance of this, stated with the estimate: 15%; middle value at least 4.0-fold (0.60 log units) from the limit.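

Replacing chloro with 4-(trifluoromethyl)phenyl on this aromatic carbon, para to a large group, gives an at least 2.5-fold higher number from compound 1 to compound 3 (0.39 log units; beyond the scatter) in this assay, so a much larger group with an added aromatic ring is tolerated here without a lower number. Compound 3 reads > 100000 nM, which is a limit of the assay and not a number, and compound 1 stays lowest of the three compounds shown. The step is therefore bounded on one side only, and its true size cannot be read: the limit of > 100000 nM in this assay, at which 1 of the 3 values shown sits.

Still open, from the compounds shown here alone, is whether the step comes with the added ring or with its trifluoromethyl group, which a plain phenyl at this place would separate. Also open, going by these compounds, is how an amine or a carboxylic acid on the added ring would read in this assay.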